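This account rests on a few compounds, and the source may have more. Where it says the series, first, only, none or still open, it means among the compounds named here.

Compound 1 `Brc1cccc(C2=NCCCC2)c1` sits in the middle of a small set of three close analogues measured in an assay on HEK293 cells for displacement of a labelled ligand from Neuronal acetylcholine receptor; alpha3/beta4 (Homo sapiens), read by radioligand binding, with a stated time of 5 min; a lower number here means a stronger inhibitor, a higher number a weaker inhibitor. In this assay compound 1 gives 29.8 nM, the second highest of the three numbers. Compound 2 `Fc1cccc(C2=NCCCC2)c1` gives 108 nM in this assay, while compound 3 `Ic1cccc(C2=NCCCC2)c1` gives 4.7 nM. The step of a 3.6-fold higher number from compound 1 to compound 2 (0.56 log units; beyond the scatter) and the step of a 6.3-fold lower number from compound 1 to compound 3 (0.80 log units; beyond the scatter) both lie beyond the scatter, and the larger step of a 23-fold lower number from compound 2 to compound 3 (1.36 log units; beyond the scatter) completes the picture. Compound 4 `Clc1cccc(C2=NCCCC2)c1` has not yet been measured in this assay. It differs from compound 1 in one place: chloro in place of bromo on an aromatic carbon. The two measured steps that start from compound 1 each exchange the bromo for fluoro or for iodo, and they point in opposite directions, a modest rise with fluoro and a modest fall with iodo. Chloro sits between those two in the set, so a modest rise in this assay relative to compound 1 is expected, smaller than the step to compound 2. Compound 4 is therefore estimated at 55 nM, with a range from 25 nM to 120 nM. This estimate means a step of a 1.8-fold higher number from compound 1 to compound 4 (0.27 log units; within the scatter).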

Compound 4, inhibition constant: 77.2 nM
Beside the measured number, compound 4's estimate is 1.4-fold (0.15 log units) below it, and the stated range covers the measured number.
By their numbers in this assay, from the lowest: compound 3; then compound 1; then compounds 4 and 2 (each within the scatter of the next).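

In this assay, chloro does not land halfway along the halogen set at this aromatic carbon. The change a 2.6-fold higher number from compound 1 to compound 4 (0.41 log units; beyond the scatter) takes it clearly away from the bromo compound, whereas a 1.4-fold lower number from compound 2 to compound 4 (0.15 log units; within the scatter) leaves it within the scatter of the fluoro compound. The four halogens therefore do not form an even ladder: fluoro and chloro stand together at the high end, and the numbers drop only with bromo and then iodo, with a 16-fold higher number from compound 3 to compound 4 (1.22 log units; beyond the scatter) spanning a large distance. As far as these compounds go, how a methoxy group or an amine at this place would compare with the halogens remains open. The data shown offer no account of why the numbers fall in this order.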